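A few compounds are considered here, and "the series" means these few. Any claim that something is new, unique, unknown or untested is made for them only; others in the source may bear on it.

Compound 1 `O=c1[nH]c(=O)n(CCC(CO)CO)cc1C#Cc1ccc(Br)cc1` is tested in a functional assay on SW-620 cells (Homo sapiens) for antiproliferative activity, read by MTT assay, with a stated time of 72 h; a lower number here means a stronger inhibitor, a higher number a weaker inhibitor. In this assay compound 1 gives > 100000 nM, which is a limit of the assay and not a measured number. Compound 2 `CCCCCc1ccc(C#Cc2cn(CCC(CO)CO)c(=O)[nH]c2=O)cc1` carries pentyl in place of bromo on an aromatic carbon. In this assay compound 2 gives > 100000 nM, also a limit. The step that the two limits leave unreadable from compound 1 to compound 2 is therefore not readable, and both values sit at the limit of > 100000 nM in this assay, at which 2 of the 2 values shown sit. Compound 3 `CCCCCC#Cc1cn(CCC(CO)CO)c(=O)[nH]c1=O` differs from compound 1 by pentyl in place of 4-bromophenyl on a triple-bonded carbon. The only measured step that touches the same part of the molecule is the unreadable one from compound 1 to compound 2, so no step of known size bears on the change toward compound 3, and on the numbers shown compound 1 stands only at the limit. Among the compounds with values here, nothing among the measured compounds points to a move beyond the scatter in either direction. Compound 3 is therefore expected to give 150000 nM, with a range from 40000 nM to 600000 nM, most likely reported again as a limit. This estimate means an expected step that the limit leaves unreadable from compound 1 to compound 3 in this assay.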

Compound 3, half-maximal inhibitory concentration: > 100000 nM
Compound 3: no number, only a limit; the forecaster's own chance of this, stated with the estimate: 85%; the middle value lies beyond the limit too.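

In this assay compound 3 gives > 100000 nM, which is a limit and not a number. Within the data shown here, no step can therefore be read from compound 1 to compound 3 or to compound 2, and the three compounds stand together: the limit of > 100000 nM in this assay, at which 3 of the 3 values shown sit. The compounds shown leave open how far any of them actually lies beyond that limit, and whether pentyl or 4-bromophenyl on the triple-bonded carbon makes any difference.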